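Series notes: aryl swaps on the aromatic nitrogen

The source may report more compounds than this note shows. Statements on the series, on what has been measured and on what is new or still open speak of the compounds shown alone.

Three measured members share one core and differ only in the aromatic group on the ring nitrogen. Compound 1 `CC1(C)[C@H]2CC[C@]1(C)N(Cc1cn(-c3ccc(C#N)cc3)nn1)C(=O)C2` gives 250 nM in a functional assay on PANC-1 cells (Homo sapiens) for inhibition, read by MTT assay, with a stated time of 24 h; on this read-out lower numbers stand for stronger inhibition and higher numbers for weaker inhibition. Compound 2 `CC1(C)[C@H]2CC[C@]1(C)N(Cc1cn(-c3cccc(C#N)c3)nn1)C(=O)C2` gives 260 nM, and compound 3 `CC1(C)[C@H]2CC[C@]1(C)N(Cc1cn(-c3ccccc3Cl)nn1)C(=O)C2` gives 270 nM. Compound 2 stands second highest of the three numbers, but its neighbours lie within the scatter on both sides: a 1.0-fold higher number from compound 1 to compound 2 (0.02 log units; within the scatter), a 1.0-fold higher number from compound 2 to compound 3 (0.02 log units; within the scatter), and across the full spread a 1.1-fold higher number from compound 1 to compound 3 (0.03 log units; within the scatter). The aryl variations tried so far therefore leave the read-out flat.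

Compound 4 `CC1(C)[C@H]2CC[C@]1(C)N(Cc1cn(-c3ccc(O)cc3)nn1)C(=O)C2` is the next member. Its change from compound 2: 4-hydroxyphenyl in place of 3-cyanophenyl on an aromatic nitrogen. Within the data shown here, no measured step introduces a hydroxyl, so the hydrogen-bond donor that enters is untested here. Among the measured compounds shown here, the steps that bear on it are the three aryl exchanges, all within the scatter, so for compound 4 the expected step is a 1.0-fold higher number from compound 2 to compound 4 (0.02 log units; within the scatter), with no direction beyond the scatter. Compound 4 is estimated at 270 nM, within a range from 120 nM to 650 nM.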

Compound 4, half-maximal inhibitory concentration: 100 nM
The estimate for compound 4 lay 2.7-fold (0.43 log units) above the measured number; measured number outside the range, below it.
By their numbers in this assay, from the lowest: compound 4; then compounds 1, 2 and 3 (each within the scatter of the next).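

In this assay the aryl group on the aromatic nitrogen no longer leaves the read-out flat: 4-hydroxyphenyl separates from all three earlier aryl groups, with a 2.6-fold lower number from compound 2 to compound 4 (0.41 log units; beyond the scatter), a 2.7-fold lower number from compound 3 to compound 4 (0.43 log units; beyond the scatter) and a 2.5-fold lower number from compound 1 to compound 4 (0.40 log units; beyond the scatter), each modest but beyond the scatter. The narrowest of these changes is hydroxy in place of cyano on an aromatic carbon, and among these four compounds only compound 4 has a hydrogen-bond donor on this aryl group, so the lower number and the donor coincide in this one compound. No measurement here accounts for the step.

On these data alone, a methoxy or an amine in place of the hydroxy would test whether the step depends on the hydroxy itself or on the donor it carries, and that remains open. Also open, as far as these compounds go, is how a carboxylic acid on the same aryl group would compare with compound 4.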